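This account rests on a few compounds, and the source may have more. Where it says the series, first, only, none or still open, it means among the compounds named here.

Measured compounds:
compound 1, `CCCCCCCCCCCCCCCCN(CCCCCCCCCCCCCCCC)[C@H](CCC(=O)NC(CCCC(N)C(=O)O)C(=O)O)C(=O)O`: 0.12 nM
compound 2, `CCCCCCCCCCCC(=O)N[C@H](CCC(=O)NC(CCCC1NC(N)=NC1=O)C(=O)O)C(=O)O`: 1.31 nM
compound 3, `CCCCCCCCCCCOC(=O)[C@H](N)CCC(=O)NC(CCCC(N)C(=O)O)C(=O)O`: 0.066 nM

These three were tested in a functional assay on HEK293 cells for agonist activity at Nucleotide-binding oligomerization domain-containing protein 1 (Homo sapiens), read by spectrophotometry; on this read-out lower numbers stand for an effect already at smaller amounts and higher numbers for an effect only at larger amounts of compound. In this assay compound 3 gives 0.066 nM, the lowest number of the three. Compound 1 lies nearest to it; its number is within the usual scatter of that of compound 3, so the two cannot be told apart. Compound 2 stands furthest away, with a number well beyond the scatter from that of compound 3.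

Compound 4, `CCCCCCCCCCCOC(=O)[C@@H](CCC(=O)NC(CCCC(N)C(=O)O)C(=O)O)NC(=N)N`, has not yet been measured. It differs from compound 3 by a group of 3 heavy atoms (1 carbon, 2 nitrogen; no ring) in place of a hydrogen atom, on an amine nitrogen. Going by the values given here, no pair of measured compounds differs in one place, so there is no measured step to lean on for this change; compound 2 carries a different arrangement of nitrogen atoms at another part of the molecule and does not speak to this step. The expectation is therefore cautious: a step from compound 3 to compound 4 that stays within the scatter, or at most a modest move toward a higher number, is what is expected, given as a 1.8-fold higher number from compound 3 to compound 4 (0.26 log units; within the scatter). On that basis compound 4 is estimated at 0.12 nM in this assay, with a range from 0.03 nM to 0.5 nM.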

Compound 4, half-maximal effective concentration: 0.238 nM
For compound 4 the middle estimate is 2.0-fold (0.30 log units) below the measured one, and the stated range covers the measured number.
By their numbers in this assay, from the lowest: compounds 3, 1 and 4 (each within the scatter of the next, the first and the last beyond it); then compound 2.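

In this assay, placing a group of 3 heavy atoms (1 carbon, 2 nitrogen; no ring) in place of a hydrogen atom on the amine nitrogen gives a 3.6-fold higher number from compound 3 to compound 4 (0.56 log units; beyond the scatter), the first step measured at this position. The number therefore responds to a change on this nitrogen, but the response is modest: the hydrogen atom of compound 3 is not needed for activity at this level, since compound 4 still reaches 0.238 nM in this assay. No measurement shown gives a reason why the number rises with this change.

The compounds shown leave open whether a single methyl group or an acetyl group on the same amine nitrogen would move the number as far, and so whether the size of the entering group or its nitrogen atoms count for more. As far as these compounds go, it also remains open whether this group would give a step of similar size with a longer chain on the ester, or with a carboxylic acid in place of that ester.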